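Bromo to Methoxy on the Aryl Ring

A few compounds are considered here, and "the series" means these few. Any claim that something is new, unique, unknown or untested is made for them only; others in the source may bear on it.

Of the compounds shown here, two that share a core have been tested in an assay on isolated protein for inhibition of Death-associated protein kinase 3 (Homo sapiens), tested at 1 uM; a higher number here means a stronger effect of the compound at the concentration tested, a lower number a weaker effect. Compound 1 `COc1ccc(C2=N/C(=C\c3cccnc3)C(=O)O2)cc1OC` gives 14%. Compound 2 `O=C1OC(c2cccc(Br)c2)=N/C1=C\c1cccnc1` gives 100%, the higher of the two numbers, and the gap to compound 1 lies beyond the scatter. Compound 3 `COc1cccc(C2=N/C(=C\c3cccnc3)C(=O)O2)c1` differs from compound 2 in one place: methoxy in place of bromo on an aromatic carbon. Going by the values given here, no measured pair shows this exact change. Because compound 1 gives 14% while carrying methoxy groups, a fall is expected. The step is estimated as a number 50 percentage points lower from compound 2 to compound 3 (beyond the scatter), beyond the scatter. Compound 3 is expected to give 50%, between 10% and 95%.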

Compound 3, a percentage reported as inhibition, at one concentration (the size of the read-out at that concentration, not a potency): 99%
Beside the measured number, compound 3's estimate is 49 percentage points below it; the measured number lies above the stated range.
By their numbers in this assay, from the lowest: compound 1; then compounds 3 and 2 (each within the scatter of the next).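

In this assay, methoxy and bromo on this aromatic carbon, meta to a large group, cannot be told apart: the swap gives a number 1 percentage points lower from compound 2 to compound 3 (within the scatter). A methoxy group alone therefore does not bring the low reading of compound 1, and removing that compound's extra methoxy, with hydrogen in its place, gives a number 85 percentage points higher from compound 1 to compound 3 (beyond the scatter). Nothing available explains either step.

Compound 2 and compound 3 both read close to full inhibition at a single concentration, so any difference in the strength of their effect at lower concentrations stays hidden. From the compounds shown here alone, whether an amine or a carboxylic acid on this carbon would keep the reading this high remains open.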